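Removing the 4-methoxyphenyl from a series at the limit

This account rests on a few compounds, and the source may have more. Where it says the series, first, only, none or still open, it means among the compounds named here.

In a functional assay on MCF7 cells (Homo sapiens) for antiproliferative activity, read by MTT assay, with a stated time of 72 h (on this read-out lower numbers stand for stronger inhibition and higher numbers for weaker inhibition), compound 3 `COc1ccc(N2C(=O)COc3ccc(-c4cnc5ccccc5c4)cc32)cc1` gives > 40000 nM, which is a limit of the assay and not a number. Compound 1 `COc1cccc(N2C(=O)COc3ccc(-c4cnc5ccccc5c4)cc32)c1` gives > 40000 nM, also a limit. Compound 2 `Cc1ccc(N2C(=O)COc3ccc(-c4cnc5ccccc5c4)cc32)cc1` gives > 40000 nM, again a limit. All three compounds therefore stand at the limit of > 40000 nM in this assay, at which 3 of the 3 values shown sit, and compound 3 cannot be ranked against the other two.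

The next compound, compound 4 `O=C1COc2ccc(-c3cnc4ccccc4c3)cc2N1`, loses the whole aryl group of compound 3: hydrogen in place of 4-methoxyphenyl on an amide-type nitrogen in a ring. Hydrogen stands in place of 4-methoxyphenyl on the amide-type nitrogen in a ring.

The measured steps bear on this only loosely, since each one exchanges one aryl group or its substituent for another and none removes the aryl group. Going by the values given here, the first is a step that the two limits leave unreadable from compound 1 to compound 2, the second is a step that the two limits leave unreadable from compound 1 to compound 3, and the third is a step that the two limits leave unreadable from compound 2 to compound 3. None of them has a readable size, so they offer no magnitude or direction to carry over to this assay.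

With nothing pointing to a gain, the expected outcome is a step that the limit leaves unreadable from compound 3 to compound 4, with compound 4 most likely remaining at the limit. The estimate for compound 4 is 45000 nM, with an expected range from 15000 nM to 100000 nM.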

Compound 4, half-maximal inhibitory concentration: > 40000 nM
Compound 4 ended at the assay's limit (the forecaster's own chance of this, stated with the estimate: 75%); the middle value lies beyond the limit too.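

Compound 4 stays at the limit with compound 1, compound 2 and compound 3 in this assay, so none of the steps to compound 4 can be read: the limit of > 40000 nM in this assay, at which 4 of the 4 values shown sit.

The compounds shown leave open whether hydrogen or any of the aryl groups on the amide-type nitrogen in a ring gives stronger or weaker inhibition than the others.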